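The compounds below may be only part of what the source reports. "The series", "measured", "known", "first", "only" and "open" are said of these compounds alone.

Compound 1 `CCCCOC(=O)CNC(=O)[C@H](CSc1ccc([N+](=O)[O-])cc1[N+](=O)[O-])NC(=O)CC[C@H](NC(=O)OC)C(=O)OCCCC`: in a toxicity assay on KB cells (Homo sapiens) for cytotoxicity, read by fluorescence, with a stated time of 3 days (on this read-out higher numbers stand for an effect only at larger amounts of compound and lower numbers for an effect already at smaller amounts), compound 1 gives > 300 uM, which is a limit of the assay.
Compound 2 `CCCCOC(=O)CNC(=O)[C@H](CSc1ccc([N+](=O)[O-])cc1[N+](=O)[O-])NC(=O)CC[C@H](NC(=O)OCc1ccccc1)C(=O)OCCCC`: in this assay compound 2 gives 95.2 uM.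
Compound 3 `CCCCOC(=O)CNC(=O)[C@H](CSc1ccc([N+](=O)[O-])cc1[N+](=O)[O-])NC(=O)CC[C@H](NC(C)=O)C(=O)OCCCC`: in this assay compound 3 gives > 300 uM, again a limit of the assay.

Compound 1 therefore has no number of its own, only a limit, and it shares that position with one other value, as the limit of > 300 uM in this assay, at which 2 of the 3 values shown sit, shows. Compound 4 `CCCCOC(=O)CNC(=O)[C@H](CSc1ccc([N+](=O)[O-])cc1[N+](=O)[O-])NC(=O)CC[C@H](NC(=O)CCc1ccccc1)C(=O)OCCCC` differs from it by phenethyl in place of methoxy on a carbonyl carbon, the change sitting on a carbonyl carbon whose other neighbours are amide-type nitrogen. Going by the values given here, two measured steps bear on this. The gain of a phenyl ring gave an at least 3.1-fold lower number from compound 1 to compound 2 (0.49 log units; beyond the scatter), and its removal together with the benzyloxy gave an at least 3.1-fold higher number from compound 2 to compound 3 (0.49 log units; beyond the scatter), while a step that the two limits leave unreadable from compound 1 to compound 3. Since compound 4 also brings in a six-membered aromatic ring, a downward step of an at least 2.7-fold lower number from compound 1 to compound 4 (0.43 log units; beyond the scatter) is expected, though with a real chance that the limit is reached once more. For compound 4 the expected value in this assay is 110 uM, within a range from 40 uM to 300 uM.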

Compound 4, concentration for half-maximal effect: > 300 uM
Compound 4: a limit, no number (the forecaster's own chance of this, stated with the estimate: 35%); middle value at least 2.7-fold (0.43 log units) away from the limit.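

The gain of a six-membered aromatic ring on this carbonyl carbon is not enough by itself to bring a number in this assay: compound 4 has only a limit, and its steps from compound 1 and compound 3 cannot be read. Phenethyl in place of benzyloxy gives an at least 3.1-fold higher number from compound 2 to compound 4 (0.49 log units; beyond the scatter), so among these compounds the ring alone does not go with the lower number, and the benzyloxy group remains the only group here that does. Most of the series now rests at one limit: the limit of > 300 uM in this assay, at which 3 of the 4 values shown sit.

Going by these compounds, whether a longer chain such as phenylpropyl, or a benzylamino group, on this carbonyl carbon would give a number stays open. On these data alone, how compound 1, compound 3 and compound 4 rank among themselves also stays open.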